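The compounds below may be only part of what the source reports. "The series", "measured", "known", "first", "only" and "open" are said of these compounds alone.

Of the compounds shown here, three have so far been measured in an assay on membranes from liver for displacement of a labelled ligand from Sigma non-opioid intracellular receptor 1 (Rattus norvegicus), read by scintillation counting; on this read-out lower numbers stand for stronger inhibition and higher numbers for weaker inhibition. Compound 1 `Cc1ccc(CN(C)CCCn2c(=O)oc3ccccc32)cc1` gives 871 nM, compound 2 `Cc1cccc(CN(C)CCCCn2c(=O)oc3ccccc32)c1` gives 102 nM, and compound 3 `O=C(NCc1ccccc1)C1CCN(Cc2ccccc2)CC1` gives 22.5 nM. On these numbers compound 2 stands second highest of the three: nearest to it is compound 3, a gap beyond the scatter, and furthest is compound 1, also beyond the scatter. Compound 4 `CN(CCCCn1c(=O)oc2ccccc21)Cc1ccc(Cl)cc1` has not yet been measured in this assay. It differs from compound 2 in one place: 4-chlorophenyl in place of 3-methylphenyl on a saturated chain carbon bound to an amine nitrogen. Among the measured compounds shown here, no step between two measured compounds that differ in one place is available to lean on, so the size of this step is open; it is expected to be small, either within the scatter or a slight move downward. Compound 4 is accordingly expected to give about 70 nM, within 25 nM to 200 nM, a step of a 1.5-fold lower number from compound 2 to compound 4 (0.16 log units; within the scatter).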

Compound 4, inhibition constant: 7.1 nM
Beside the measured number, compound 4's estimate is 9.9-fold (0.99 log units) above it; measured number outside the range, below it.
By their numbers in this assay, from the lowest: compound 4; then compound 3; then compound 2; then compound 1.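

In this assay, among the compounds shown here, 4-chlorophenyl in place of 3-methylphenyl gives a 14-fold lower number from compound 2 to compound 4 (1.16 log units; beyond the scatter), so a change confined to this aromatic ring, with the heavy-atom count unchanged, can move the number strongly, which no earlier pair could show. Nothing available accounts for the size of this step. From the compounds shown here alone, whether the step follows the chlorine itself or its place on the ring stays open: the swap changes both at once, and 3-chlorophenyl on the same chain would part the two.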